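The compounds below may be only part of what the source reports. "The series", "measured", "known", "first", "only" and "open" are said of these compounds alone.

In a functional assay on ileum (Cavia porcellus) for antagonist activity, with a stated time of 30 s (a lower number here means a stronger inhibitor, a higher number a weaker inhibitor), compound 1 `O=C(O)c1cc(=O)c2ccc(OCCCCCOc3ccccc3)cc2o1` gives 0.4 ug/mL. Compound 2 `O=C(O)c1cc(=O)c2ccc(OCCCCCOc3cccc(O)c3)cc2o1`, with hydroxy in place of hydrogen on an aromatic carbon, gives 1.5 ug/mL. Compound 3 `COc1cccc(OCCCCCOc2ccc3c(=O)cc(C(=O)O)oc3c2)c1`, with methoxy in place of that hydrogen, gives 1.5 ug/mL. Both changes are modest but beyond the scatter: a 3.8-fold higher number from compound 1 to compound 2 (0.57 log units; beyond the scatter) and a 3.8-fold higher number from compound 1 to compound 3 (0.57 log units; beyond the scatter). Swapping one added group for the other shows nothing measurable: no change at the digits printed from compound 2 to compound 3 (within the scatter). Compound 3 therefore stands level with compound 2, and the two share the highest number of the three.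

Compound 4 `CC(=O)c1ccc(OCCCCCOc2ccc3c(=O)cc(C(=O)O)oc3c2)cc1` has 4-acetylphenyl in place of 3-methoxyphenyl on an oxygen on a saturated carbon. Among the measured compounds shown here, no measured step covers an acetyl group, so the guide is indirect. Two different added groups gave the same number, and compound 4 also carries an added group, so it is expected to stay near compound 3 at 1.5 ug/mL. The expected step in this assay is small and slightly downward, with nothing beyond the scatter: a 1.3-fold lower number from compound 3 to compound 4 (0.10 log units; within the scatter). For compound 4 the estimate is 1.2 ug/mL, with an expected range of 0.4 ug/mL to 3.5 ug/mL.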

Compound 4, half-maximal inhibitory concentration: 3.5 ug/mL
Compound 4: the middle estimate sits 2.9-fold (0.46 log units) below what was measured; measured number inside the range.
By their numbers in this assay, from the lowest: compound 1; then compounds 2 and 3 (each within the scatter of the next); then compound 4.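

The 4-acetylphenyl group separates from the two earlier added groups, which could not be told apart in this assay: there is a 2.3-fold higher number from compound 3 to compound 4 (0.37 log units; beyond the scatter) and a 2.3-fold higher number from compound 2 to compound 4 (0.37 log units; beyond the scatter). At this end of the chain, then, the identity of the added group matters, not just its presence, and compound 4 has the highest number of the four, with an 8.8-fold higher number from compound 1 to compound 4 (0.94 log units; beyond the scatter) as the largest step. No measurement here explains this difference.

The change from 3-methoxyphenyl to 4-acetylphenyl alters both the group and the number in its name, so the compounds shown cannot separate the effect of the acetyl group from that of its place on the ring. Going by these compounds, how an amine or a carboxylic acid on this ring would read also remains open.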